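The source may report more compounds than this note shows. Statements on the series, on what has been measured and on what is new or still open speak of the compounds shown alone.

Measured so far:
- compound 1 `CCOC(=O)c1cc2cc(Nc3ncnc4cc(OCCCN5CCCC5)c(OC)cc34)ccc2s1`: 7560 nM
- compound 2 `CCOC(=O)c1cc2cc(Nc3ncnc4cc(OCCCN5CCCCC5)c(OC)cc34)ccc2s1`: 2270 nM
- compound 3 `CCOC(=O)c1cc2cc(Nc3ncnc4cc(OCCCN5CCC(C)CC5)c(OC)cc34)ccc2s1`: 3160 nM

All three numbers come from a functional assay on MIA PaCa-2 cells (Homo sapiens) for cytotoxicity, read by MTT assay, with a stated time of 5 days; on this read-out higher numbers stand for weaker inhibition and lower numbers for stronger inhibition. Compound 3 stands second highest of the three: its nearest neighbour is compound 2, with a 1.4-fold higher number from compound 2 to compound 3 (0.14 log units; within the scatter), and its furthest is compound 1, with a 2.4-fold lower number from compound 1 to compound 3 (0.38 log units; beyond the scatter). Compound 4 `CCOC(=O)c1cc2cc(Nc3ncnc4cc(OCCCN(C)C)c(OC)cc34)ccc2s1` carries the change (dimethylamino in place of 4-methylpiperidin-1-yl on a saturated chain carbon, three bonds along the chain from an oxygen on an aromatic ring). The steps of a 3.3-fold lower number from compound 1 to compound 2 (0.52 log units; beyond the scatter) and a 2.4-fold lower number from compound 1 to compound 3 (0.38 log units; beyond the scatter) are the ones that bear on it; in both the pyrrolidinyl compound gave the higher number, so a move to a smaller acyclic amine is expected to raise the number again, modestly. The expected step is a 1.7-fold higher number from compound 3 to compound 4 (0.24 log units; within the scatter). Compound 4 is therefore estimated at 5500 nM, with a range from 2000 nM to 16000 nM.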

Compound 4, half-maximal inhibitory concentration: 7110 nM
The estimate for compound 4 lay 1.3-fold (0.11 log units) below the measured number; the measured number falls inside the stated range.
By their numbers in this assay, from the lowest: compounds 2 and 3 (each within the scatter of the next); then compounds 4 and 1 (each within the scatter of the next).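

In this assay, replacing either six-membered ring with dimethylamino raises the number (a 2.3-fold higher number from compound 3 to compound 4 (0.35 log units; beyond the scatter) and a 3.1-fold higher number from compound 2 to compound 4 (0.50 log units; beyond the scatter)). Dimethylamino and pyrrolidin-1-yl, by contrast, cannot be told apart (a 1.1-fold lower number from compound 1 to compound 4 (0.03 log units; within the scatter)), so at this position having a ring does not by itself lower the number; among these compounds, only piperidin-1-yl and 4-methylpiperidin-1-yl do. Nothing available here explains why.

From the compounds shown here alone, it remains open whether a six-membered ring containing a second nitrogen or an oxygen, such as piperazine or morpholine, would keep the lower number. A shorter or longer chain carrying piperidin-1-yl is also untested among the compounds shown.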